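The source may hold more compounds than are shown below. What is called first, only, known or untested is meant among the compounds shown, and "the series" means these compounds.

Measured compounds:
compound 1 `Cc1ccc(S(=O)(=O)NC(=O)Nc2ccccc2C(=O)/C=C/c2ccccc2)cc1`, 25 ug/mL
compound 2 `Cc1ccc(/C=C/C(=O)c2ccccc2NC(=O)NS(=O)(=O)c2ccc(C)cc2)cc1`, 15.3 ug/mL
compound 3 `COc1cc(/C=C/C(=O)c2ccccc2NC(=O)NS(=O)(=O)c2ccc(C)cc2)ccc1O`, 17.8 ug/mL

All values come from an ADME assay on the whole organism for cytotoxicity, with Artemia salina as the target, with a stated time of 24 h; a lower number here means that less compound is needed, a higher number that more compound is needed for the effect. Compound 3 stands second highest of the three numbers; the gaps to the others are a 1.2-fold higher number from compound 2 to compound 3 (0.07 log units; within the scatter) and a 1.4-fold lower number from compound 1 to compound 3 (0.15 log units; within the scatter), both within the scatter, so no ordering among the three can be claimed. Compound 4 `Cc1ccc(S(=O)(=O)NC(=O)Nc2ccccc2C(=O)/C=C/c2cccc([N+](=O)[O-])c2)cc1` is not yet measured. The change from compound 3 is 3-nitrophenyl in place of 4-hydroxy-3-methoxyphenyl on a double-bonded chain carbon bound to a double-bonded chain carbon. Within the data shown here, two measured steps touch the same place, a 1.4-fold lower number from compound 1 to compound 3 (0.15 log units; within the scatter) and a 1.2-fold higher number from compound 2 to compound 3 (0.07 log units; within the scatter), and neither exceeds the scatter. Among the measured compounds shown here, no measured compound carries a nitro group, so nothing further bears on this step. The step is expected to remain within the scatter, a 1.1-fold higher number from compound 3 to compound 4 (0.05 log units; within the scatter). Compound 4 is estimated at 20 ug/mL, range 10 ug/mL to 40 ug/mL.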

Compound 4, concentration for half-maximal effect: 44.5 ug/mL
Beside the measured number, compound 4's estimate is 2.2-fold (0.35 log units) below it; measured number outside the range, above it.
By their numbers in this assay, from the lowest: compounds 2, 3, 1 and 4 (each within the scatter of the next, the first and the last beyond it).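

In this assay, among these compounds, 3-nitrophenyl on a double-bonded chain carbon bound to a double-bonded chain carbon gives the first steps at this position that exceed the scatter (a 2.5-fold higher number from compound 3 to compound 4 (0.40 log units; beyond the scatter); a 2.9-fold higher number from compound 2 to compound 4 (0.46 log units; beyond the scatter)). Against the unsubstituted phenyl of compound 1, however, nitro in place of hydrogen stays within the scatter (a 1.8-fold higher number from compound 1 to compound 4 (0.25 log units; within the scatter)), so only part of the series resolves from compound 4. No supporting measurement accounts for these steps.

Among the compounds shown here, with compound 4 the only nitro example, it remains open whether the steps are specific to nitro. An amine or a carboxylic acid in its place would test this.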